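Ether side chains on the shared core: towards compound 4

The source may report more compounds than this note shows. Statements on the series, on what has been measured and on what is new or still open speak of the compounds shown alone.

Three ethers of the shared core have been measured. Compound 1 `CC1CCC(Oc2cccc3ccc(N)nc23)C1` carries 3-methylcyclopentyl on an oxygen on an aromatic ring, and in an assay on cells with melanin-concentrating hormone receptor 1 (Homo sapiens) as the target, read by radioligand binding (on this read-out higher numbers stand for weaker inhibition and lower numbers for stronger inhibition), compound 1 gives 823 nM. Compound 2 `CCOCC(C)Oc1cccc2ccc(N)nc12` gives 1070 nM in this assay; it stands as the higher of the two plain numbers, yet a 1.3-fold higher number from compound 1 to compound 2 (0.11 log units; within the scatter). Compound 3 `Nc1ccc2cccc(OCC3CCCO3)c2n1` reaches only a limit of this assay: compound 3 gives > 2000 nM. Measured against that limit, an at least 2.4-fold higher number from compound 1 to compound 3 (0.38 log units; beyond the scatter), while an at least 1.8-fold higher number from compound 2 to compound 3 (0.27 log units; that floor lies within the scatter); both of these rest on (the limit of > 2000 nM in this assay, at which 1 of the 3 values shown sits).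

Compound 4 `CC(COC(C)(C)C)Oc1cccc2ccc(N)nc12` is not yet measured. It differs from compound 2 in tert-butyl in place of ethyl on an oxygen on a saturated carbon. Among the compounds with values here, no measured step touches this position: the steps among compound 1, compound 2 and compound 3 all exchange the whole group on the oxygen on the aromatic ring, and the only one that keeps an open chain there, from compound 1 to compound 2, stays within the scatter. The chain of compound 2 is retained in compound 4, so no step beyond the scatter is expected in this assay; the expected step is a 1.0-fold higher number from compound 2 to compound 4 (0.01 log units; within the scatter). Compound 4 is therefore estimated at 1100 nM, with a range from 500 nM to 2400 nM.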

Compound 4, half-maximal inhibitory concentration: 306 nM
Compound 4: middle estimate off by 3.6-fold (0.56 log units), on the high side; the whole stated range lies above it.
By their numbers in this assay, from the lowest: compound 4; then compounds 1 and 2 (each within the scatter of the next). At a limit, above all of these: compound 3.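

Notes on the ether side chain: a change on an oxygen on a saturated carbon, well inside the retained chain of compound 2, moves the read-out in this assay, with tert-butyl in place of ethyl giving a 3.5-fold lower number from compound 2 to compound 4 (0.54 log units; beyond the scatter). The earlier steps shown here exchanged the whole group on the oxygen on the aromatic ring, so they could not show that this one place, taken alone, responds beyond the scatter and in the direction of stronger inhibition. The data shown give no cause for this step, and the only supporting information concerns a limit reached by a different compound.

Going by these compounds, this is a single pair, ethyl and tert-butyl, so it stays open whether intermediate or other groups here, such as isopropyl, cyclopropyl or a longer chain such as n-butyl, would follow the same direction. On these data alone, it also stays open whether an amine or a carboxylic acid at this place would be tolerated, and whether tert-butyl would give a similar step on other side chains of the shared core.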